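Urea series: fluoro to trifluoromethyl on the aryl ring

The source may hold more compounds than are shown below. What is called first, only, known or untested is meant among the compounds shown, and "the series" means these compounds.

Compound 1 `Cn1ncc2c(NC(=O)NCc3cc(C(F)(F)F)nn3-c3ccc(F)cc3)cccc21` gives 8.4 nM in an assay on CHO-K1 cells for antagonist activity at transient receptor potential cation channel subfamily V member 1 (Homo sapiens), read by FLIPR and calcium flux, with a stated time of 6 min; a lower number here means a stronger inhibitor, a higher number a weaker inhibitor. Compound 2 `Cn1ncc2c(NC(=O)NCc3cc(C(F)(F)F)nn3-c3ccc(C(F)(F)F)cc3)cccc21`, which carries trifluoromethyl in place of fluoro on an aromatic carbon, gives 3.9 nM in this assay; the step is a 2.2-fold lower number from compound 1 to compound 2 (0.33 log units; beyond the scatter). Compound 3 `Cn1ncc2c(NC(=O)NCc3cc(C(C)(C)C)nn3-c3ccc(F)cc3)cccc21` differs from compound 1 in its core by tert-butyl in place of trifluoromethyl on an aromatic carbon; in this assay compound 3 gives 4.5 nM, and the step is a 1.9-fold lower number from compound 1 to compound 3 (0.27 log units; within the scatter). Compound 2 and compound 3 sit within the scatter of each other.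

Compound 4 `Cn1ncc2c(NC(=O)NCc3cc(C(C)(C)C)nn3-c3ccc(C(F)(F)F)cc3)cccc21` is not yet measured. It differs from compound 3 by trifluoromethyl in place of fluoro on an aromatic carbon, the same change already seen from compound 1 to compound 2. Because a 2.2-fold lower number from compound 1 to compound 2 (0.33 log units; beyond the scatter) was a modest step beyond the scatter, a comparable step is expected here, a 2.3-fold lower number from compound 3 to compound 4 (0.35 log units; beyond the scatter), resting on that single precedent in this assay. Compound 4 is therefore estimated at 2 nM in this assay, between 0.9 nM and 4.5 nM.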

Compound 4, inhibition constant: 12.4 nM
Estimate against measurement, compound 4: 6.2-fold (0.79 log units) below, outside the stated range (above it).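

In this assay, trifluoromethyl in place of fluoro does not carry over from the core of compound 1 to the core of compound 3, as the new step, a 2.8-fold higher number from compound 3 to compound 4 (0.44 log units; beyond the scatter), runs the opposite way: the same change on two cores in this assay, a 2.2-fold lower number (0.33 log units; beyond the scatter) from compound 1 to compound 2 and a 2.8-fold higher number (0.44 log units; beyond the scatter) from compound 3 to compound 4, 5.9-fold (0.77 log units) apart, beyond the scatter of two such steps. Tert-butyl in place of trifluoromethyl likewise depends on the aryl group, with a 3.2-fold higher number from compound 2 to compound 4 (0.50 log units; beyond the scatter) on the 4-(trifluoromethyl)phenyl side: the same change on two cores in this assay, a 1.9-fold lower number (0.27 log units; within the scatter) from compound 1 to compound 3 and a 3.2-fold higher number (0.50 log units; beyond the scatter) from compound 2 to compound 4, 5.9-fold (0.77 log units) apart, beyond the scatter of two such steps. The two places therefore do not act independently across these four compounds, but the data do not show why, or whether this holds beyond them.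

Open, from the compounds shown here alone, is whether chloro or a nitrile on the same aromatic carbon, or isopropyl in place of tert-butyl, would show the same dependence.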